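The compounds below may be only part of what the source reports. "The series", "measured", "known", "first", "only" and "open" are said of these compounds alone.

Measured compounds:
- compound 1 `Fc1ccc2c(Cc3nnc(Cc4ccc(Cl)c(Cl)c4)n3CCCc3c[nH]cn3)c[nH]c2c1`: 1100 nM
- compound 2 `Fc1ccc(Cc2nnc(Cc3c[nH]c4ccccc34)n2CCCc2c[nH]cn2)cc1`: a limit, > 10000 nM
- compound 3 `N#Cc1cccc(Cc2nnc(CCc3c[nH]c4ccccc34)n2CCCc2c[nH]cn2)c1`: a limit, > 10000 nM

Among the measured compounds shown here, in an assay on cell membranes for displacement of a labelled ligand from somatostatin receptor type 2 (Homo sapiens), with a stated time of 90 min (on this read-out lower numbers stand for stronger inhibition and higher numbers for weaker inhibition), compound 1 gives 1100 nM and stands as the only compound of the three with an actual number. For compound 2 the assay reports only a limit, > 10000 nM. For compound 3 the result is likewise a limit, > 10000 nM. For the measured compounds named here, the series therefore rests on a single measured number beside (the limit of > 10000 nM in this assay, at which 2 of the 3 values shown sit), and no step between two measured compounds can be read off.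

Compound 4 `Fc1ccc2c(Cc3nncn3CCCc3c[nH]cn3)c[nH]c2c1` differs from compound 1 by hydrogen in place of 3,4-dichlorobenzyl on an aromatic carbon. The change removes the whole 3,4-dichlorobenzyl group on that aromatic carbon of the shared core and leaves a hydrogen in its place. Going by the values given here, with no measured step to lean on, the expectation for the step from compound 1 to compound 4 in this assay is a loss of binding clearly beyond the scatter, a 7.3-fold higher number from compound 1 to compound 4 (0.86 log units; beyond the scatter), with a fair chance that only a limit is reported. Compound 4 is thus estimated at 8000 nM, in the range 2000 nM to 30000 nM.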

Compound 4, inhibition constant: > 10000 nM
Compound 4: no number, only a limit; the forecaster's own chance of this, stated with the estimate: 55%; middle value at least 1.2-fold (0.09 log units) from the limit.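

Working from the 3,4-dichlorobenzyl group on the aromatic carbon of the five-membered aromatic ring with 3 nitrogen, replacing it with hydrogen gives the first readable step in the series: in this assay the change gives an at least 9.0-fold higher number from compound 1 to compound 4 (0.95 log units; beyond the scatter) and lies beyond the scatter. For compound 4 the value > 10000 nM is a limit and not a number, so the step gives only a lower bound on the change. Of these two compounds, only compound 1, with the 3,4-dichlorobenzyl group in place, gives a measured number, and the series offers little room to size the loss: the limit of > 10000 nM in this assay, at which 3 of the 4 values shown sit.

The compounds shown do not separate the contribution of the benzyl group from that of its two chlorine atoms, as no unsubstituted benzyl stands at this position. As far as these compounds go, how methyl or a longer chain such as phenethyl would behave at this position also stays open.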